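The source may report more compounds than this note shows. Statements on the series, on what has been measured and on what is new or still open speak of the compounds shown alone.

Compound 1, `C[C@@H](NC(=O)Nc1ccccc1C(C)(C)C)c1ccccc1`, is the weaker-read compound of the two measured here. In an ADME assay on the whole organism with Oryza sativa as the target, tested at 10 uM (a lower number here means a stronger effect, a higher number a weaker effect of the compound at the concentration tested), compound 1 gives 17%, the lowest of the two numbers shown, and thus the strongest effect among them. For the measured compounds named here, its only measured neighbour is compound 2, `C[C@@H](NC(=O)Nc1ccccc1Cl)c1ccccc1`, which in this assay gives 93%; the step of a number 76 percentage points higher from compound 1 to compound 2 (beyond the scatter) comes with chloro in place of tert-butyl on an aromatic carbon, and it lies beyond the scatter.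

Compound 3, `C[C@@H](NC(=O)Nc1cc(C(C)(C)C)ccc1C(C)(C)C)c1ccccc1`, is not yet measured. It differs from compound 1 by tert-butyl in place of hydrogen on an aromatic carbon: a second tert-butyl group enters, on an aromatic carbon of the six-membered aromatic ring of carbon only, para to a tert-butyl group. Going by the values given here, the one step that bears on this change runs in the opposite sense: taking the tert-butyl away raised the number by a large margin in this assay. Adding a further tert-butyl is therefore expected to leave the number low, with little room to fall further. Compound 3 is expected to give an estimated 14%, within 0% to 42%, a step of a number 3 percentage points lower from compound 1 to compound 3 (within the scatter) that is expected to stay within the scatter.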

Compound 3, a percentage reported as activity, at one concentration (the size of the read-out at that concentration, not a potency): 99%
Compound 3: the middle estimate sits 85 percentage points below what was measured; the measured number lies above the stated range.
By their numbers in this assay, from the lowest: compound 1; then compounds 2 and 3 (each within the scatter of the next).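

In this assay, a second tert-butyl on the aromatic carbon para to a tert-butyl group and meta to a large group comes with a number 82 percentage points higher from compound 1 to compound 3 (beyond the scatter), so this position does not tolerate the change without losing the low number of compound 1. The earlier step, a number 76 percentage points higher from compound 1 to compound 2 (beyond the scatter), tied that low number to the tert-butyl group already on the ring, but compound 3 keeps that group and still loses it, so that group alone does not secure the low number and the substitution at this second position matters as well. Nothing available here accounts for why the added tert-butyl has so large an effect on the number.

On these data alone, whether a methyl or a methoxy group on the same aromatic carbon would move the number as far as tert-butyl does, or leave it near that of compound 1, remains open. As far as these compounds go, it is also open whether a tert-butyl at this position would have a comparable effect on compound 2, which carries chloro in place of the first tert-butyl.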